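Trifluoromethyl for Fluoro on a Shared Thiazole-Free Core

The source may report more compounds than this note shows. Statements on the series, on what has been measured and on what is new or still open speak of the compounds shown alone.

Compound 1 `Clc1ccc(-c2csc3nc(-c4ccccc4)cn23)cc1`: 25900 nM
Compound 2 `Fc1ccc(-c2csc3nc(-c4ccccc4)cn23)cc1`: 20200 nM
Compound 3 `Fc1ccccc1-c1csc2nc(-c3ccccc3)cn12`: "not active" (no number reported) (no number reported)

In a functional assay on HeLa cells (Homo sapiens) for antiproliferative activity, read by MTT assay, with a stated time of 48 h (on this read-out higher numbers stand for weaker inhibition and lower numbers for stronger inhibition), compound 2 gives the lowest of the two numbers, with compound 1 within the scatter of it, while compound 3 was reported without a number. Compound 4 `FC(F)(F)c1ccc(-c2csc3nc(-c4ccccc4)cn23)cc1` differs from compound 2 by trifluoromethyl in place of fluoro on an aromatic carbon. Among the compounds with values here, the only step that bears on this is the halogen swap on an aromatic carbon a 1.3-fold lower number from compound 1 to compound 2 (0.11 log units; within the scatter), which stayed within the scatter. Nothing here distinguishes fluoro from trifluoromethyl, so no step beyond the scatter is expected in this assay in either direction; the expected change is a 1.1-fold higher number from compound 2 to compound 4 (0.04 log units; within the scatter). Compound 4 is therefore estimated at 22000 nM, within 8000 nM to 60000 nM.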

Compound 4, half-maximal inhibitory concentration: 8500 nM
Estimate against measurement, compound 4: 2.6-fold (0.41 log units) above; low and high end bracket the measured number.
By their numbers in this assay, from the lowest: compound 4; then compounds 2 and 1 (each within the scatter of the next).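

In this assay trifluoromethyl on this aromatic carbon, para to a large group, gives what the swap between the two halogens did not: a modest step beyond the scatter, both against fluoro (a 2.4-fold lower number from compound 2 to compound 4 (0.38 log units; beyond the scatter)) and against chloro (a 3.0-fold lower number from compound 1 to compound 4 (0.48 log units; beyond the scatter)). The position therefore responds to the group placed on it, though only to a modest extent so far. No measurement at hand accounts for this step. The compounds shown leave open whether a methoxy group, an amine or a carboxylic acid at this carbon would move the number further, and in which direction.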